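This account rests on a few compounds, and the source may have more. Where it says the series, first, only, none or still open, it means among the compounds named here.

Compound 3 `CC(=O)Nc1cccc(NC(=O)COc2ccc3c(=O)ccoc3c2)c1` gives 136 nM in an assay on isolated protein for inhibition of Rho-associated protein kinase 2 (Homo sapiens), read by scintillation counting, radiometric assay and 33P incorporation, with a stated time of 40 min, in the presence of a further agent that is not named here; a higher number here means a weaker inhibitor, a lower number a stronger inhibitor. Compound 1 `COc1cc(OCC(=O)Nc2cccc(NC(=O)c3ccc(N(C)C)cc3)c2)ccc1C=O` gives 306 nM in this assay. Compound 2 `Cc1c(OCC(=O)Nc2cccc(NC(=O)c3ccc(N(C)C)cc3)c2)ccc2c(=O)ccoc12` gives 4160 nM in this assay.

Compound 3 stands lowest of the three numbers; compound 1 is the nearest, with a higher number beyond the scatter, and compound 2 the furthest, also beyond the scatter. Compound 4 `COc1ccc(C(=O)Nc2cccc(NC(=O)COc3ccc4c(=O)ccoc4c3)c2)cc1` has not yet been measured. It differs from compound 3 in one place: 4-methoxyphenyl in place of methyl on a carbonyl carbon. Among the compounds with values here, no step between measured compounds isolates this change, so the size is uncertain; a moderate weakening is expected, and the step from compound 3 to compound 4 is estimated as a 2.2-fold higher number from compound 3 to compound 4 (0.34 log units; beyond the scatter). Compound 4 is therefore expected to give about 300 nM in this assay, within 80 nM to 1200 nM.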

Compound 4, half-maximal inhibitory concentration: 7 nM
Compound 4: middle estimate off by 43-fold (1.63 log units), on the high side, outside the stated range (below it).
By their numbers in this assay, from the lowest: compound 4; then compound 3; then compound 1; then compound 2.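

On a carbonyl carbon whose other neighbour is an amide-type nitrogen, the shared core accepts much more than a methyl: in this assay, 4-methoxyphenyl in place of methyl gives a 19-fold lower number from compound 3 to compound 4 (1.29 log units; beyond the scatter). The earlier compounds shown here offered no step at this position, and this one shows that it responds strongly and that the larger group is favoured over methyl. Nothing measured here bears on why the number falls so far.

The compounds shown leave open whether the ring alone carries this step or the methoxy group on it does, since plain phenyl is not among them. As far as these compounds go, how a saturated cyclohexyl ring would compare at this position also remains open.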